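This account rests on a few compounds, and the source may have more. Where it says the series, first, only, none or still open, it means among the compounds named here.

In an ADME assay on SH-SY5Y cells (Homo sapiens) for cytotoxicity, read by MTT assay, with a stated time of 48 h (a lower number here means that less compound is needed, a higher number that more compound is needed for the effect), compound 1 (`O=C(O)c1ccccc1-c1ccccc1C(=O)NCCCCCCCn1cc(-c2cccnc2)nn1`) gives > 500 nM. This is a limit of the assay and not a number, so compound 1 can be placed only by the limit of > 500 nM in this assay, at which 1 of the 2 values shown sits.

Compound 2 (`O=C(NCCCCCCCn1cc(-c2cccnc2)nn1)c1ccccc1-n1ccnn1`) carries 1H-1,2,3-triazol-1-yl in place of 2-carboxyphenyl on an aromatic carbon, and it reads 35.4 nM. Among the compounds with values here, that swap is the only measured step available here, and it is large: an at least 14-fold lower number from compound 1 to compound 2 (1.14 log units; beyond the scatter).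

Compound 3 (`CN(C)Cc1cn(-c2ccccc2C(=O)NCCCCCCCn2cc(-c3cccnc3)nn2)nn1`) has not yet been measured. It keeps the core of compound 1 but replaces the same 2-carboxyphenyl group with 4-((dimethylamino)methyl)-1H-1,2,3-triazol-1-yl, a change counted as 4-((dimethylamino)methyl)-1H-1,2,3-triazol-1-yl in place of 2-carboxyphenyl on an aromatic carbon. The entering group is also a 1H-1,2,3-triazol-1-yl, so the step to compound 2, an at least 14-fold lower number from compound 1 to compound 2 (1.14 log units; beyond the scatter), is the best guide, and a similarly large move towards a lower number is expected. This rests on one step alone, so the range must stay wide. The expected step is an at least 11-fold lower number from compound 1 to compound 3 (1.04 log units; beyond the scatter). For compound 3, the estimated value is 45 nM, with an expected range from 12 nM to 170 nM.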

Compound 3, half-maximal effective concentration: 285 nM
Compound 3: the middle estimate sits 6.3-fold (0.80 log units) below what was measured; the whole stated range lies below it.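

On this aromatic carbon, the 1H-1,2,3-triazol-1-yl ring does not settle the read-out by itself. Placing (dimethylamino)methyl in place of hydrogen on an aromatic carbon gives an 8.1-fold higher number from compound 2 to compound 3 (0.91 log units; beyond the scatter) in this assay, so what the ring carries matters as well, and more compound is needed for the effect once this group is present. The swap from the original group gives an at least 1.7-fold lower number from compound 1 to compound 3 (0.24 log units; that floor lies within the scatter), and the true size of this step stays unknown because compound 1 is held only by a limit: the limit of > 500 nM in this assay, at which 1 of the 3 values shown sits.

The compounds shown leave open whether the rise belongs to the dimethylamino part or to any group on that ring carbon, and a plain methyl group in place of the same hydrogen would help to separate the two. They also leave open whether a primary amine or a longer chain between the ring and the amine would keep the number nearer that of compound 2 or move it further towards that of compound 3.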